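A few compounds are considered here, and "the series" means these few. Any claim that something is new, unique, unknown or untested is made for them only; others in the source may bear on it.

Measured compounds:
- compound 1, `CCCCCCCCCCCCCCCCCCNC(=O)[C@@H](N)[C@@H](C)O`, in a functional assay on SW-620 cells (Homo sapiens) for cytotoxicity, read by MTT assay, with a stated time of 48 h (a lower number here means a stronger inhibitor, a higher number a weaker inhibitor), compound 1 gives 21400 nM
- compound 2, `CCCCCCCCCCCCCCNC(=O)[C@@H](NC(=O)c1ccco1)[C@@H](C)O`, in this assay compound 2 gives 200000 nM
- compound 3, `CCCCCCCCCCCCCCCCCCNC(=O)[C@@H](NC(=O)c1ccccc1)[C@@H](C)O`, in this assay compound 3 gives 200000 nM

Compound 3 stands level with compound 2 at the digits shown, the two together giving the highest numbers of the three. Within the data shown here, its only single-point step is a 9.3-fold higher number from compound 1 to compound 3 (0.97 log units; beyond the scatter), the benzoyl on the amine nitrogen in place of hydrogen.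

Compound 4, `CCCCCCCCCCCCCCCCCCNC(=O)[C@@H](NC(=O)c1ccco1)[C@@H](C)O`, is the next step from compound 3: furan-2-yl in place of phenyl on a carbonyl carbon. Among the measured compounds shown here, no measured step bears directly on this exchange. Compound 2 carries the same furan-2-yl carbonyl on a shorter chain and its value and that of compound 3 do not differ at the digits shown, which is all that pair can show. The step from hydrogen to benzoyl was modest and the furan analogue on the other chain sits at the same number, so for this assay no step beyond the scatter is expected: no change at the digits printed from compound 3 to compound 4 (within the scatter). Compound 4 is therefore estimated at 200000 nM, in the range 80000 nM to 400000 nM.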

Compound 4, half-maximal inhibitory concentration: > 200000 nM
Compound 4: a limit, no number; the forecaster's own chance of this, stated with the estimate: 25%; the middle value lies on the limit itself.
By their numbers in this assay, from the lowest: compound 1; then compounds 2 and 3 (each within the scatter of the next).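

In this assay compound 4 gives > 200000 nM, which is a limit of the assay and not a number: the limit of > 200000 nM in this assay, at which 1 of the 4 values shown sits.

On the shared chain, a second acyl group on the amine nitrogen now also gives a step beyond the scatter, an at least 9.3-fold higher number from compound 1 to compound 4 (0.97 log units; beyond the scatter), so this holds for (furan-2-yl)carbonyl as well as for benzoyl. Neither a number no lower from compound 3 to compound 4 (the limit leaves the size open) nor a number no lower from compound 2 to compound 4 (the limit leaves the size open) can be read, so the exchange of phenyl for furan-2-yl and the chain change cannot be sized here.

Open, going by these compounds, is how a small acyl group such as acetyl, or a simple alkyl group such as methyl, on that nitrogen would read in this assay. Also open, on these data alone, is how a shorter chain would read when the free amine of compound 1 is kept.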